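The source may report more compounds than this note shows. Statements on the series, on what has been measured and on what is new or still open speak of the compounds shown alone.

In an assay on isolated protein for binding affinity to adenosine receptor A1 (Bos taurus) (on this read-out lower numbers stand for stronger inhibition and higher numbers for weaker inhibition), compound 1 `OC1CCC(Nc2nc(-c3ccccc3)nc3c2nnn3Cc2ccccc2F)CC1` gives 1850000 nM. Compound 2 `OC1CCC(Nc2nc(-c3ccccc3)nc3c2nnn3Cc2ccccc2Cl)CC1` gives 3100000 nM, and compound 3 `CCCCCCNc1nc(-c2ccccc2)nc2c1nnn2Cc1ccccc1Cl` gives 31000000 nM. Compound 1 carries the smallest number of the three, though the step of a 1.7-fold higher number from compound 1 to compound 2 (0.22 log units; within the scatter) stays within the scatter, while the step of a 10-fold higher number from compound 2 to compound 3 (1.00 log units; beyond the scatter) sets compound 3 clearly apart. Compound 4 `CCNc1nc(-c2ccccc2)nc2c1nnn2Cc1ccccc1F` differs from compound 1 in one place: ethyl in place of 4-hydroxycyclohexyl on a nitrogen on an aromatic ring. The step that bears on this is a 10-fold higher number from compound 2 to compound 3 (1.00 log units; beyond the scatter), where hexyl also replaced the 4-hydroxycyclohexyl group on the nitrogen and binding became weaker. A loss of similar kind is therefore expected for compound 4, a 4.9-fold higher number from compound 1 to compound 4 (0.69 log units; beyond the scatter), and compound 4 is estimated at 9000000 nM with a range from 3000000 nM to 30000000 nM.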

Compound 4, inhibition constant: 11000000 nM
Compound 4: the middle estimate sits 1.2-fold (0.09 log units) below what was measured; the range from low to high includes it.
By their numbers in this assay, from the lowest: compounds 1 and 2 (each within the scatter of the next); then compound 4; then compound 3.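

Putting ethyl on this nitrogen gives a 5.9-fold higher number from compound 1 to compound 4 (0.77 log units; beyond the scatter) and so shows that the weakening first seen with hexyl in a 10-fold higher number from compound 2 to compound 3 (1.00 log units; beyond the scatter) is not confined to that one chain or to the chloro compound. Each chain now gives a higher number than the 4-hydroxycyclohexyl compound it replaces, in both the fluoro and chloro pairs. On these data alone, whether the ring or its hydroxyl group matters stays open, and a plain cyclohexyl group on this nitrogen would separate the two. Nothing shown here explains the loss in binding.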